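The source may report more compounds than this note shows. Statements on the series, on what has been measured and on what is new or still open speak of the compounds shown alone.

Measured so far:
compound 1, `CCc1ccc(N2C(=O)NC3(CSC4=C3C(=O)c3ncccc3C4=O)C2=O)cc1`: 5 nM
compound 2, `Cc1ccc(N2NC(=O)NC3(CSC4=C3C(=O)c3ncccc3C4=O)C2=O)cc1`: 210 nM

Both numbers come from a functional assay on HeLa cells (Homo sapiens) for antiproliferative activity, read by MTT assay, with a stated time of 96 h; on this read-out higher numbers stand for weaker inhibition and lower numbers for stronger inhibition. Compound 1 gives 5 nM, the lower of the two numbers, and compound 2 gives 210 nM; the gap between them lies beyond the usual scatter. Within the data shown here, compound 2 differs from compound 1 in more than one place, so the two values show only that compound 1 is the stronger inhibitor of this pair.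

Compound 3, `CC(C)(C)c1ccc(N2C(=O)NC3(CSC4=C3C(=O)c3ncccc3C4=O)C2=O)cc1`, has not yet been tested in this assay. It differs from compound 1 in a single change: tert-butyl in place of ethyl on an aromatic carbon. The group that enters is the larger of the two. Among the measured compounds shown here, with no measured pair of this kind to draw on, the expected outcome is a small rise in the number, close to the scatter, so that compound 3 is estimated to keep most of the strength of compound 1, with a step of a 2.0-fold higher number from compound 1 to compound 3 (0.30 log units; within the scatter). Compound 3 is therefore expected to give about 10 nM, within a range from 3 nM to 40 nM.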

Compound 3, half-maximal inhibitory concentration: 100 nM
Beside the measured number, compound 3's estimate is 10-fold (1.00 log units) below it; measured number outside the range, above it.
By their numbers in this assay, from the lowest: compound 1; then compound 3; then compound 2.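

In this assay, putting tert-butyl in place of ethyl on the aromatic carbon para to a large group gives a 20-fold higher number from compound 1 to compound 3 (1.30 log units; beyond the scatter). Among these compounds, this is the first comparison that isolates this position, and it shows that the position is not indifferent to the group it carries: one change to a small carbon-only group, with no ring, donor, acceptor or charge involved, costs most of the strength of compound 1. Nothing measured here gives a reason for this rise.

On the core of compound 1, only ethyl and tert-butyl are shown at this position, and one step cannot reveal how the number moves across a wider set of groups. On these data alone, how an isopropyl group, a methoxy group or an amine would read at this same carbon remains open.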